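Swapping benzyl for 4-methoxyphenyl: expected affinity step

The compounds below may be only part of what the source reports. "The series", "measured", "known", "first", "only" and "open" are said of these compounds alone.

Three compounds have been measured in an assay for binding affinity to Alpha-1A adrenergic receptor (Homo sapiens); a lower number here means a stronger inhibitor, a higher number a weaker inhibitor:
compound 1, `CN1CCC[C@@H]1Cn1nc(Cc2ccc(F)cc2)c2ccccc2c1=O`, gives 63.1 nM
compound 2, `O=c1c2ccccc2c(Cc2ccc(Cl)cc2)nn1C[C@H]1CCCN1CCCCCc1ccc(OCCCN2CCCCCC2)cc1`, gives 25.1 nM
compound 3, `CN1CCC[C@@H]1Cn1nc(CCc2ccccc2)c2ccccc2c1=O`, gives 200 nM

Compound 3 stands at the highest number of the three, that is, it is the weakest binder among them. Among the measured compounds shown here, its nearest neighbour is compound 1, and the only single-change step in the set connects these two: a 3.2-fold higher number from compound 1 to compound 3 (0.50 log units; beyond the scatter). For the measured compounds named here, compound 2 carries a much larger change and has no direct step to compound 3.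

Compound 4, `COc1ccc(Cc2nn(C[C@H]3CCCN3C)c(=O)c3ccccc23)cc1`, is not yet measured. It differs from compound 3 in one place: 4-methoxyphenyl in place of benzyl on a saturated chain carbon bound to an aromatic carbon.

The step from compound 1 to compound 3 bears directly on this change, since it also exchanges a ring bearing a substituent on its six-membered aromatic ring for a benzyl group at the same place, only in the other direction. That step was modest and went toward a higher number. Going back from benzyl to a substituted ring is therefore expected to give a modest step toward a lower number, though whether methoxy behaves like fluoro is not shown by any compound here.

For compound 4 in this assay the expected step is a 2.9-fold lower number from compound 3 to compound 4 (0.46 log units; beyond the scatter). Compound 4 is estimated at 70 nM, with a range from 25 nM to 200 nM.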

Compound 4, inhibition constant: 126 nM
The estimate for compound 4 lay 1.8-fold (0.26 log units) below the measured number; measured number inside the range.
By their numbers in this assay, from the lowest: compound 2; then compounds 1, 4 and 3 (each within the scatter of the next, the first and the last beyond it).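

In this assay, 4-methoxyphenyl in place of benzyl gives a 1.6-fold lower number from compound 3 to compound 4 (0.20 log units; within the scatter) and methoxy in place of fluoro on an aromatic carbon gives a 2.0-fold higher number from compound 1 to compound 4 (0.30 log units; within the scatter) so neither change can be told apart from the ordinary variation between repeated measurements. Before this result, the only single-change step at this place was the one between compound 1 and compound 3, which lay beyond the scatter and could be read as a clear contrast between a ring-substituted benzyl group and phenethyl. Compound 4 now sits within the scatter of both, so having a substituent on the ring does not by itself separate the compounds clearly, and nothing available explains this outcome.

The compounds shown leave open whether a group of a different kind on the same aromatic carbon, such as an amine, a carboxylic acid or a nitrile, would move the number beyond the scatter. They also leave open how a longer chain than phenethyl would behave at this place, with the rest of compound 3 kept unchanged.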